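Semicarbazone anilinoquinazolines: cytotoxicity on A549, methoxy pair

The source may report more compounds than this note shows. Statements on the series, on what has been measured and on what is new or still open speak of the compounds shown alone.

Measured so far:
compound 1 `O=C(N/N=C/c1cc(Br)c(O)c(Br)c1)Nc1cc2c(Nc3ccc(F)c(Cl)c3)ncnc2cc1O[C@H]1CCOC1`, 8910 nM
compound 2 `O=C(N/N=C/c1ccc(O)cc1O)Nc1cc2c(Nc3ccc(F)c(Cl)c3)ncnc2cc1O[C@H]1CCOC1`, 9360 nM
compound 3 `COc1cc2ncnc(Nc3ccc(F)c(Cl)c3)c2cc1NC(=O)N/N=C/c1cc(Br)c(O)c(Br)c1`, 34600 nM

All three were read in a functional assay on A549 cells (Homo sapiens) for cytotoxicity, read by MTT assay, with a stated time of 72 h; on this read-out higher numbers stand for weaker inhibition and lower numbers for stronger inhibition. Compound 1 and compound 2 differ only at the acylhydrazone end, (2,4-dihydroxyphenyl in place of 3,5-dibromo-4-hydroxyphenyl on a carbon with a double bond to nitrogen); the step is a 1.1-fold higher number from compound 1 to compound 2 (0.02 log units; within the scatter), so the two numbers cannot be told apart. Compound 1 and compound 3 differ in the core, (methyl in place of oxolan-3-yl on an oxygen on an aromatic ring); that step is a 3.9-fold higher number from compound 1 to compound 3 (0.59 log units; beyond the scatter), and compound 3 carries the highest number of the three.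

Compound 4 `COc1cc2ncnc(Nc3ccc(F)c(Cl)c3)c2cc1NC(=O)N/N=C/c1ccc(O)cc1O` is not yet measured. It stands to compound 3 as compound 2 stands to compound 1: 2,4-dihydroxyphenyl in place of 3,5-dibromo-4-hydroxyphenyl on a carbon with a double bond to nitrogen. The place of the change is described in the same words for both pairs, so it is the same change on a different core.

Because the earlier step of a 1.1-fold higher number from compound 1 to compound 2 (0.02 log units; within the scatter) stayed within the scatter, the step from compound 3 to compound 4 is expected to be about as small, estimated at a 1.1-fold higher number from compound 3 to compound 4 (0.03 log units; within the scatter). On that basis compound 4 is expected to give about 37000 nM in this assay, with a likely range from 15000 nM to 90000 nM. Within the data shown here, with only one prior instance of the change, on a different core, the width of the range is kept generous.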

Compound 4, half-maximal inhibitory concentration: 31400 nM
Compound 4: the middle estimate sits 1.2-fold (0.07 log units) above what was measured; low and high end bracket the measured number.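

In this assay the exchange at the acylhydrazone end gives a 1.1-fold lower number from compound 3 to compound 4 (0.04 log units; within the scatter) and so leaves the number unchanged within the scatter on the core of compound 3, as it did on the core of compound 1: the same change on two cores in this assay, a 1.1-fold higher number (0.02 log units; within the scatter) from compound 1 to compound 2 and a 1.1-fold lower number (0.04 log units; within the scatter) from compound 3 to compound 4, 1.2-fold (0.06 log units) apart, within the scatter of two such steps. Methyl in place of oxolan-3-yl gives a 3.4-fold higher number from compound 2 to compound 4 (0.53 log units; beyond the scatter) and so raises the number with 2,4-dihydroxyphenyl as it did with 3,5-dibromo-4-hydroxyphenyl: the same change on two cores in this assay, a 3.9-fold higher number (0.59 log units; beyond the scatter) from compound 1 to compound 3 and a 3.4-fold higher number (0.53 log units; beyond the scatter) from compound 2 to compound 4, 1.2-fold (0.06 log units) apart, within the scatter of two such steps. Across these four compounds the two changes therefore behave independently, but this rests on one pair of aryl groups, one pair of groups on the oxygen and one cell read-out, and it shows neither a general rule for the series nor a cause for either step.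

Open, from the compounds shown here alone, is whether the same independence holds with a longer chain or a chain ending in an amine on that oxygen. Also open, going by these compounds, is whether it holds with an unsubstituted phenyl on the carbon with a double bond to nitrogen.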